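Trimming compound 3 down to a 4-hydroxyphenyl group

The source may report more compounds than this note shows. Statements on the series, on what has been measured and on what is new or still open speak of the compounds shown alone.

Of the compounds shown here, three sharing one core have been tested in a functional assay on PC-3 cells (Homo sapiens) for cytotoxicity, read by MTT assay, with a stated time of 72 h; a lower number here means a stronger inhibitor, a higher number a weaker inhibitor. Compound 1 `COc1ccc(/C=N/NC(=O)Nc2cc3c(Nc4ccc(F)c(Cl)c4)ncnc3cc2O[C@H]2CCOC2)c(OC)c1OC` gives 25600 nM, compound 2 `O=C(N/N=C/c1ccc(O)c(Br)c1)Nc1cc2c(Nc3ccc(F)c(Cl)c3)ncnc2cc1O[C@H]1CCOC1` gives 5230 nM, and compound 3 `CCN(CC)c1ccc(/C=N/NC(=O)Nc2cc3c(Nc4ccc(F)c(Cl)c4)ncnc3cc2O[C@H]2CCOC2)c(O)c1` gives 4590 nM. Compound 3 therefore stands level with compound 2 at the low end of these numbers, clearly apart from compound 1.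

The unmeasured compound 4 `O=C(N/N=C/c1ccc(O)cc1)Nc1cc2c(Nc3ccc(F)c(Cl)c3)ncnc2cc1O[C@H]1CCOC1` differs from compound 3 in one place: 4-hydroxyphenyl in place of 4-(diethylamino)-2-hydroxyphenyl on a carbon with a double bond to nitrogen.

Three measured steps change this same place. Leaving the 2,3,4-trimethoxyphenyl group gave a 4.9-fold lower number from compound 1 to compound 2 (0.69 log units; beyond the scatter) and a 5.6-fold lower number from compound 1 to compound 3 (0.75 log units; beyond the scatter), both modest. Exchanging one hydroxy-bearing group for the other gave a 1.1-fold lower number from compound 2 to compound 3 (0.06 log units; within the scatter), so two quite different groups gave values that cannot be told apart. Three compounds are a thin basis, and none of them carries the plain 4-hydroxyphenyl group, so this is only a guide. Compound 4 also has a hydroxy-bearing group, so it is expected to sit with compound 2 and compound 3, near 4590 nM. The expected change is a 1.3-fold higher number from compound 3 to compound 4 (0.12 log units; within the scatter), with no step beyond the scatter. Compound 4 is estimated at 6000 nM, with an expected range from 2500 nM to 18000 nM.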

Compound 4, half-maximal inhibitory concentration: 4890 nM
Compound 4: middle estimate off by 1.2-fold (0.09 log units), on the high side, within the range that was stated.
By their numbers in this assay, from the lowest: compounds 3, 4 and 2 (each within the scatter of the next); then compound 1.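

In this assay, the plain 4-hydroxyphenyl group does as well as 4-(diethylamino)-2-hydroxyphenyl, which has more heavy atoms, with a 1.1-fold higher number from compound 3 to compound 4 (0.03 log units; within the scatter), and taking away the bromo on an aromatic carbon gives a 1.1-fold lower number from compound 2 to compound 4 (0.03 log units; within the scatter), so neither the diethylamino group nor the bromo is needed for a value in this range. For the compounds shown here, the smallest group of the set also stays clearly apart from 2,3,4-trimethoxyphenyl, with a 5.2-fold lower number from compound 1 to compound 4 (0.72 log units; beyond the scatter), which leaves the three compounds with a hydroxy group on this ring together and the one with only methoxy groups on its own. Nothing in the available data explains why such different groups give values that cannot be told apart.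

From the compounds shown here alone, it remains open whether the hydroxy group itself matters, since it is the comparison with a plain phenyl group or a 4-methoxyphenyl group on this carbon that would separate its part from that of the rest of the ring. Also open, going by these compounds, is whether a quite different group here, such as a ring carrying a carboxylic acid or a pyridine ring, would move the number away from this cluster at all.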